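Trifluoromethyl gives way to fluoro on an aromatic ring

The compounds below may be only part of what the source reports. "The series", "measured", "known", "first", "only" and "open" are said of these compounds alone.

In an ADME assay on L02 cells (Homo sapiens) for cytotoxicity, read by MTT assay, with a stated time of 24 h (a lower number here means a stronger inhibitor, a higher number a weaker inhibitor), compound 1 (`O=C1/C(=C/c2ccncc2)CNC/C1=C\c1ccccc1F`) gives 14700 nM and compound 2 (`O=C1/C(=C/c2ccncc2)CN(S(=O)(=O)c2ccc(C(F)(F)F)cc2)C/C1=C\c1ccccc1F`) gives 18600 nM as its reading. Within the data shown here, these two values lie within the scatter of each other, so compound 2 stands level with compound 1 on the numbers so far. Compound 3 (`O=C1/C(=C/c2ccncc2)CN(S(=O)(=O)c2ccc(F)cc2)C/C1=C\c1ccccc1F`) has not yet been measured. It differs from compound 2 in one place, with fluoro in place of trifluoromethyl on an aromatic carbon, para to a large group (fluoro in place of trifluoromethyl on an aromatic carbon). Among the measured compounds shown here, no measured pair shows this change, so the data give no direct guide to it. No step beyond the scatter is expected in this assay in either direction. The estimated step of a 1.2-fold lower number from compound 2 to compound 3 (0.07 log units; within the scatter) is expected to stay within the scatter. Compound 3 is expected at 16000 nM in this test, with an estimated range from 8000 nM to 32000 nM on repeated measurement.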

Compound 3, half-maximal inhibitory concentration: 15600 nM
The estimate for compound 3 lay 1.0-fold (0.01 log units) above the measured number; the range from low to high includes it.
By their numbers in this assay, from the lowest: compounds 1, 3 and 2 (each within the scatter of the next).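

In this assay the change from 4-(trifluoromethyl)phenyl to 4-fluorophenyl gives a 1.2-fold lower number from compound 2 to compound 3 (0.08 log units; within the scatter) and so shows that, on this aromatic carbon para to a large group, fluoro and trifluoromethyl leave the reading level. Placing (4-fluorophenyl)sulfonyl in place of hydrogen on the ring amine nitrogen gives a 1.1-fold higher number from compound 1 to compound 3 (0.03 log units; within the scatter) and so adds a second sulfonyl compound that stands level with the unsubstituted amine of compound 1. No measurement shown here bears on why these readings stay level.

Still open, from the compounds shown here alone, is whether a methoxy group, a nitrile, an amine or a carboxylic acid on that same aromatic carbon would also stay within the scatter. Also open, going by these compounds, is whether an acetyl group or a benzyl group on the ring nitrogen would read level with the sulfonyl compounds.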